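The source may report more compounds than this note shows. Statements on the series, on what has been measured and on what is new or still open speak of the compounds shown alone.

Measured compounds:
- compound 1 `O=C(Nc1ccc2nc(NC(=O)C3CCCCC3)sc2c1)c1cccnc1Cl` — 0.075 ug/mL in a functional assay on WI-38 VA13 cells (Homo sapiens) for cytotoxicity; on this read-out lower numbers stand for an effect already at smaller amounts and higher numbers for an effect only at larger amounts of compound
- compound 2 `CC(C)CC(=O)Nc1nc2ccc(NC(=O)c3c(Cl)cccc3Cl)cc2s1` — 0.012 ug/mL in this assay

Of the two numbers in this assay, compound 2 gives the lowest; the nearest number, that of compound 1, stands higher by a gap that is beyond the usual scatter. For the measured compounds named here, no pair of measured compounds differs in only one place, so no single-point step has been observed.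

Compound 3 `CC(C)(C)OC(=O)Nc1nc2ccc(NC(=O)c3c(Cl)cccc3Cl)cc2s1` has not been measured in this assay. Relative to compound 2 the change is tert-butoxy in place of isobutyl on a carbonyl carbon. Going by the values given here, no measured pair shares this change, and both measured compounds keep a carbonyl attached to the amide-type nitrogen, as does compound 3. The step from compound 2 to compound 3 is therefore expected to be modest, and its direction is uncertain, with a number for compound 3 expected to stay close to the value of compound 2 rather than reach that of compound 1, giving an expected step of a 2.5-fold higher number from compound 2 to compound 3 (0.40 log units; beyond the scatter). For compound 3 the estimate in this assay is 0.03 ug/mL, with a range from 0.008 ug/mL to 0.12 ug/mL.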

Compound 3, half-maximal effective concentration: 0.027 ug/mL
Estimate against measurement, compound 3: 1.1-fold (0.05 log units) above; measured number inside the range.
By their numbers in this assay, from the lowest: compound 2; then compound 3; then compound 1.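

In this assay, the series now has its first single-point step, on a carbonyl carbon whose other neighbour is the amide-type nitrogen: tert-butoxy in place of isobutyl gives a 2.3-fold higher number from compound 2 to compound 3 (0.35 log units; beyond the scatter). This position therefore responds to the exchange, modestly but beyond the scatter, when the carbon count stays the same and one oxygen and one hydrogen-bond acceptor enter. No measurement at hand bears on the cause of this step.

One step cannot separate the entering oxygen from the altered arrangement of the carbons, and neopentyl on the same carbonyl carbon would address that question directly. Also open, as far as these compounds go, are the effects of an amine, a carboxylic acid or a longer chain at this place, and whether the exchange gives a similar step with the remaining groups of compound 1.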